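Triazole substituent swap on a shared lactone core

This account rests on a few compounds, and the source may have more. Where it says the series, first, only, none or still open, it means among the compounds named here.

Measured compounds:
compound 1, `O=C1O[C@H]([C@@H](O)Cn2cc(-c3cc(C(F)(F)F)cc(C(F)(F)F)c3)nn2)C(OCc2ccccc2)=C1OCc1ccccc1`: 45900 nM
compound 2, `O=C1O/C(=C\Cn2cc(-c3cc(C(F)(F)F)cc(C(F)(F)F)c3)nn2)C(OCc2ccccc2)=C1OCc1ccccc1`: > 100000 nM
compound 3, `CCCCCCCCCCc1cn(C[C@H](O)[C@H]2OC(=O)C(OCc3ccccc3)=C2OCc2ccccc2)nn1`: 80 nM

Of the compounds shown here, three have been measured in a functional assay on MCF7 cells (Homo sapiens) for antiproliferative activity, read by MTT assay, with a stated time of 72 h; on this read-out higher numbers stand for weaker inhibition and lower numbers for stronger inhibition. Compound 3, which carries a decyl chain on its triazole, gives 80 nM and stands lowest of the two numbers, well beyond the scatter from compound 1, whose bis(trifluoromethyl)phenyl-bearing analogue gives 45900 nM. Compound 2 reaches only (the limit of > 100000 nM in this assay, at which 1 of the 3 values shown sits), so for it the assay reports a limit and not a number.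

The unmeasured compound 4, `COc1ccc(-c2cn(C[C@H](O)[C@H]3OC(=O)C(OCc4ccccc4)=C3OCc3ccccc3)nn2)cc1`, departs from compound 3 in a single place: 4-methoxyphenyl in place of decyl on an aromatic carbon. An aryl group thus again takes the place of the long chain, as in compound 1, though with a different substitution pattern. Among the measured compounds shown here, no direct pair of measured compounds isolates this exact change, so the expectation rests on the contrast between compound 3 and compound 1. Compound 4 is expected to sit far above compound 3 in this assay, a step of a 250-fold higher number from compound 3 to compound 4 (2.40 log units; beyond the scatter) toward weaker inhibition, though it is estimated to remain somewhat stronger than compound 1. For compound 4 the estimated value is 20000 nM, with a range from 3000 nM to 100000 nM.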

Compound 4, half-maximal inhibitory concentration: 99700 nM
Compound 4: the middle estimate sits 5.0-fold (0.70 log units) below what was measured, within the range that was stated.
By their numbers in this assay, from the lowest: compound 3; then compound 1; then compound 4. At a limit, above all of these: compound 2.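

In this assay, the aromatic carbon of the five-membered ring with 3 nitrogen now has a second aryl group to set against the decyl chain, and a 1200-fold higher number from compound 3 to compound 4 (3.10 log units; beyond the scatter) shows that the low number of compound 3 is lost again when 4-methoxyphenyl enters. The earlier contrast rested on the bis(trifluoromethyl)phenyl group alone, but the loss is now seen with a differently substituted aryl group as well: compound 1 gives 45900 nM and compound 4 gives 99700 nM, both far from the value of compound 3. Nothing measured in this set explains why this step is so large.

The compounds shown place only a single chain at this position, so they leave open whether a shorter chain such as hexyl or a longer one such as dodecyl would keep the low number of compound 3. From the compounds shown here alone, it also remains open whether a decyl chain ending in an amine or a carboxylic acid, or a benzyl group that separates the aryl ring from the ring carbon, would hold any of that inhibition.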